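From Ethyl Ester to Hydrazide: Weak Activity Expected

The source may hold more compounds than are shown below. What is called first, only, known or untested is meant among the compounds shown, and "the series" means these compounds.

Measured compounds:
compound 1 `O=[N+]([O-])c1ccc2[nH]c(CSCc3nc4cc([N+](=O)[O-])ccc4[nH]3)nc2c1` — 2250 nM
compound 2 `CCOC(=O)CSCc1nc2cc([N+](=O)[O-])ccc2[nH]1` — > 100000 nM

In a functional assay on HepG2 cells (Homo sapiens) for cytotoxicity, read by MTT assay, with a stated time of 48 h (a lower number here means a stronger inhibitor, a higher number a weaker inhibitor), compound 1 gives 2250 nM. For compound 2 this assay reports only a limit, > 100000 nM, which is the limit of > 100000 nM in this assay, at which 1 of the 2 values shown sits. Compound 3 `NNC(=O)CSCc1nc2cc([N+](=O)[O-])ccc2[nH]1` differs from compound 2 by aminoamino in place of ethoxy on a carbonyl carbon. Within the data shown here, with no step between measured compounds to lean on, the step of an at least 1.2-fold lower number from compound 2 to compound 3 (0.09 log units; that floor lies within the scatter) is expected to be small and of uncertain direction. Compound 3 is therefore estimated at 80000 nM, in a range from 20000 nM to 300000 nM, with a real chance that this assay again reports only a limit.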

Compound 3, half-maximal inhibitory concentration: 18600 nM
The estimate for compound 3 lay 4.3-fold (0.63 log units) above the measured number; the whole stated range lies above it.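

Swapping ethoxy for aminoamino on a carbonyl carbon gives an at least 5.3-fold lower number from compound 2 to compound 3 (0.73 log units; beyond the scatter) in this assay, so a change at this position can move the number by more than the scatter. That step is a floor and not a full size. Compound 2 stands only at a limit of the assay: the limit of > 100000 nM in this assay, at which 1 of the 3 values shown sits. The compounds shown leave open whether a plain amine-derived amide, a carboxylic acid or a methylamino group on the same carbonyl carbon would move the number likewise, and so which part of aminoamino matters.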